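The source may hold more compounds than are shown below. What is called first, only, known or untested is meant among the compounds shown, and "the series" means these compounds.

Measured so far:
compound 1, `Cc1ccccc1Nc1nnc(Nc2nc(-c3ccccc3)cs2)s1`, in a functional assay on the whole organism (strain albino) with Mus musculus as the target, in the maximal electroshock model, with a stated time of 0.5 h (a higher number here means that more compound is needed for the effect, a lower number that less compound is needed), gives 300 mg/kg
compound 2, `Cc1ccc(Nc2nnc(Nc3nc(-c4ccccc4)cs3)s2)cc1`, gives 100 mg/kg

Among the measured compounds shown here, compound 2 holds the lowest number of the two; the single measured step, a 3.0-fold lower number from compound 1 to compound 2 (0.48 log units; beyond the scatter), separates it from compound 1.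

Compound 3, `COc1ccccc1Nc1nnc(Nc2nc(-c3ccccc3)cs2)s1`, is not yet measured. (2-methoxyphenyl in place of 4-methylphenyl on a nitrogen on an aromatic ring). For the measured compounds named here, the only step that bears on this is a 3.0-fold lower number from compound 1 to compound 2 (0.48 log units; beyond the scatter), where exchanging 2-methylphenyl for 4-methylphenyl lowered the number. Compound 3 returns to a 2-substituted ring, with 2-methoxyphenyl, for which no direct comparison exists. A step upward of about that size is therefore expected, a 3.0-fold higher number from compound 2 to compound 3 (0.48 log units; beyond the scatter). Compound 3 is estimated at 300 mg/kg, in the range 100 mg/kg to 1000 mg/kg.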

Compound 3, minimum effective dose: 100 mg/kg
Compound 3: middle estimate off by 3.0-fold (0.48 log units), on the high side, and the stated range covers the measured number.
By their numbers in this assay, from the lowest: compounds 2 and 3 (each within the scatter of the next); then compound 1.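

In this assay, methoxy in place of methyl on an aromatic carbon lowers the number (a 3.0-fold lower number from compound 1 to compound 3 (0.48 log units; beyond the scatter)), so moving to 4-methylphenyl is not the only change on this nitrogen that does so. 2-Methoxyphenyl in place of 4-methylphenyl leaves the number unchanged (no change at the digits printed from compound 2 to compound 3 (within the scatter)), so the high number of compound 1 belongs to 2-methylphenyl and not to every 2-substituted phenyl shown here. No measurement at hand accounts for either step.

On these data alone, whether ethoxy, chlorine or an amine on the same ring would keep this number remains open.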